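This account rests on a few compounds, and the source may have more. Where it says the series, first, only, none or still open, it means among the compounds named here.

Measured in an assay on isolated protein for inhibition of Amine oxidase [flavin-containing] B (Homo sapiens), read by fluorescence and Amplex Red, with a stated time of 30 min; a lower number here means a stronger inhibitor, a higher number a weaker inhibitor:

compound 1 `COc1cc(C2=NNC(c3ccc(Cl)cc3)C2)ccc1O` gives 140000 nM
compound 2 `COc1cc(C2=NN(S(=O)(=O)c3ccc(C)cc3)C(c3ccc(Cl)cc3)C2)ccc1O` gives 6000000 nM
compound 3 `COc1cc(C2=NN(C(=S)Nc3ccccc3)C(c3ccc(Cl)cc3)C2)ccc1O` gives 4770000 nM

Compound 2 carries the highest number of the three. Against compound 1 the gap is a 43-fold higher number from compound 1 to compound 2 (1.63 log units; beyond the scatter), whereas a 1.3-fold lower number from compound 2 to compound 3 (0.10 log units; within the scatter) lies within the scatter, so compound 2 and compound 3 are not separated by these data.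

Compound 4 `COc1cc(C2=NN(C(=O)Oc3ccccc3)C(c3ccc(Cl)cc3)C2)ccc1O` differs from compound 2 in one place: phenoxycarbonyl in place of (4-methylphenyl)sulfonyl on an amine nitrogen in a ring. Among the compounds with values here, three measured steps bear on this. The two steps that put a substituent on the same nitrogen in place of hydrogen, a 43-fold higher number from compound 1 to compound 2 (1.63 log units; beyond the scatter) and a 34-fold higher number from compound 1 to compound 3 (1.53 log units; beyond the scatter), were both large and in the same direction. Within the data shown here, the one step that exchanged one such substituent for another, a 1.3-fold lower number from compound 2 to compound 3 (0.10 log units; within the scatter), stayed within the scatter. The change to compound 4 is again an exchange of one substituent for another on that nitrogen, of comparable count of heavy atoms and acceptors. For compound 4 the expected step in this assay is therefore none beyond the scatter, a 1.2-fold lower number from compound 2 to compound 4 (0.08 log units; within the scatter). The estimate for compound 4 is 5000000 nM, with a range from 1500000 nM to 15000000 nM.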

Compound 4, inhibition constant: 5770000 nM
Beside the measured number, compound 4's estimate is 1.2-fold (0.06 log units) below it; low and high end bracket the measured number.
By their numbers in this assay, from the lowest: compound 1; then compounds 3, 4 and 2 (each within the scatter of the next).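

On the ring nitrogen, phenoxycarbonyl in place of (4-methylphenyl)sulfonyl gives a 1.0-fold lower number from compound 2 to compound 4 (0.02 log units; within the scatter) in this assay and the exchange of the thiourea-type group of compound 3 for phenoxycarbonyl gives a 1.2-fold higher number from compound 3 to compound 4 (0.08 log units; within the scatter) so compounds 2, 3 and 4 are not separated by these data. A third kind of link to the aromatic ring, a carbonyl with an oxygen, therefore leaves the number where the sulfonyl and the thiocarbonyl links had it. Phenoxycarbonyl in place of hydrogen gives a 41-fold higher number from compound 1 to compound 4 (1.62 log units; beyond the scatter) making this the third large step in the same direction from compound 1, with no substituent shown going against it, and nothing measured here accounts for the size of that step.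

On this nitrogen the compounds carry only hydrogen or a group ending in a six-membered aromatic ring. Going by these compounds, whether a methyl, an acetyl or a chain ending in an amine there would stay near compound 1 or join compounds 2, 3 and 4 remains open.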